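The source may report more compounds than this note shows. Statements on the series, on what has been measured and on what is new or still open speak of the compounds shown alone.

Working notes on a small series read in an ADME assay on Vero cells (Chlorocebus sabaeus) for cytotoxicity, with a stated time of 72 h, tested at 50 ug/mL (a higher number here means a stronger effect of the compound at the concentration tested, a lower number a weaker effect), three compounds measured and one still open.

Compound 1 `O=c1[nH]nc2n(c1=O)CCN2c1ccccc1` gives 30% in this assay. Compound 2 `Cc1ccccc1N1CCn2c1n[nH]c(=O)c2=O` gives 0% in this assay. Within the data shown here, the two differ in one place, (hydrogen in place of methyl on an aromatic carbon), and the step is a number 30 percentage points higher from compound 2 to compound 1 (beyond the scatter); it is the only counted step between measured compounds in the set.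

Compound 3 `Cc1ccc(N2CCn3c2n[nH]c(=O)c3=N)cc1` stands on a different core from compound 2; the difference between the two cores is not broken down here. In this assay compound 3 gives 0%, level with compound 2 at the digits printed and within the scatter of it, so no order is claimed between those two. The gap from compound 3 to compound 1 is beyond the scatter, with compound 3 the lower of the pair.

Compound 4 `N=c1c(=O)[nH]nc2n1CCN2c1ccccc1` is not yet measured. It differs from compound 3 as hydrogen in place of methyl on an aromatic carbon. Set beside the step from compound 2 to compound 1, the place is not the same word for word: there the hydrogen enters ortho to a large group, here para to a large group, and the core is that of compound 3 rather than compound 2. The change is therefore of the same kind, not the same.

Compound 4 is expected to give 15% in this assay, within 0% to 40%. Among the measured compounds shown here, the expected step of a number 15 percentage points higher from compound 3 to compound 4 (beyond the scatter) is set smaller than the earlier one because the only precedent, a number 30 percentage points higher from compound 2 to compound 1 (beyond the scatter), rests on one pair on another core and at another place.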

Compound 4, a percentage reported as inhibition, at one concentration (the size of the read-out at that concentration, not a potency): 30%
Beside the measured number, compound 4's estimate is 15 percentage points below it; measured number inside the range.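

In this assay, hydrogen in place of methyl on an aromatic carbon gives a number 30 percentage points higher from compound 3 to compound 4 (beyond the scatter), so the methyl-bearing compound again sits at the lower end of its pair. Set beside the earlier pair, the change carries from one core to the other with no difference in size that can be told apart: the same change on two cores in this assay, a number 30 percentage points higher (beyond the scatter) from compound 2 to compound 1 and a number 30 percentage points higher (beyond the scatter) from compound 3 to compound 4, 0 percentage points apart, within the scatter of two such steps

This agreement rests on two pairs and a single concentration, and the place also differs between them, with the hydrogen in compound 4 para to a large group and the hydrogen in the earlier pair elsewhere on the ring, so the effect of the core cannot be separated from that of the place, and neither pair gives a reason for the step or shows that it would hold on any further core.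

The compounds shown leave open how the read-out in this assay would respond to other groups on the aromatic ring, such as a methoxy group, a chlorine atom, an amine or a carboxylic acid. They also leave open whether a longer chain, such as ethyl or propyl, in place of methyl would follow the same step on either core.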